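A Level Series Meets a New Side Chain

The compounds below may be only part of what the source reports. "The series", "measured", "known", "first", "only" and "open" are said of these compounds alone.

In a functional assay on MCF7 cells (Homo sapiens) for inhibition, read by MTT assay, with a stated time of 3 days (a lower number here means a stronger inhibitor, a higher number a weaker inhibitor), compound 1 `COc1cc(-c2nc3ccccc3s2)ccc1OCC(=O)NNC(=O)CN[C@@H](CCSC)C(=O)O` gives 1950 nM and so stands level with compound 2 `COc1cc(-c2nc3ccccc3s2)ccc1OCC(=O)NNC(=O)CNC(=N)NCCC[C@H](N[N+](=O)[O-])C(=O)O` at 1960 nM and compound 3 `CCOC(=O)[C@@H](NCC(=O)NNC(=O)COc1ccc(-c2nc3ccccc3s2)cc1OC)[C@@H](C)CC` at 1950 nM (all within the scatter of repeat measurements). Compound 4 `CCOC(=O)[C@H](CS)N(CC(=O)NNC(=O)COc1ccc(-c2nc3ccccc3s2)cc1OC)C(C)=O` has not yet been measured. It keeps the core of compound 1 and changes one side chain: acetyl(1-(ethoxycarbonyl)-2-sulfanylethyl)amino in place of (1-carboxy-3-(methylsulfanyl)propyl)amino on a saturated chain carbon bound to a carbonyl carbon.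

The measured step that bears most directly on this change is the swap of 1-carboxy-3-(methylsulfanyl)propyl for 1-(ethoxycarbonyl)-2-methylbutyl on an amine nitrogen (no change at the digits printed from compound 1 to compound 3 (within the scatter)), which also brings in an ethoxycarbonyl group. Compound 2 carries a different chain again, yet its value matches the other two. Among the measured compounds shown here, the acetyl on the nitrogen and the free sulfanyl have no measured example in this small set, so the forecast stays uncertain. With only level values to go on, no step beyond the scatter is expected in this assay and the estimated step (a 1.0-fold higher number from compound 1 to compound 4 (0.01 log units; within the scatter)) has no clear direction. The estimate for compound 4 is 2000 nM with 1100 nM to 3800 nM as its expected range.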

Compound 4, half-maximal inhibitory concentration: 1890 nM
Beside the measured number, compound 4's estimate is 1.1-fold (0.02 log units) above it, and the stated range covers the measured number.
By their numbers in this assay, from the lowest: compounds 4, 1, 3 and 2 (each within the scatter of the next).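

In this assay, acetyl(1-(ethoxycarbonyl)-2-sulfanylethyl)amino on a saturated chain carbon bound to a carbonyl carbon gives a 1.0-fold lower number from compound 1 to compound 4 (0.01 log units; within the scatter) when it takes the place of (1-carboxy-3-(methylsulfanyl)propyl)amino, and a 1.0-fold lower number from compound 3 to compound 4 (0.01 log units; within the scatter) when it takes the place of (1-(ethoxycarbonyl)-2-methylbutyl)amino. Both steps stay within the scatter, so this position keeps the same reading even when its nitrogen carries an acetyl and the side chain holds a free sulfanyl, two features absent from compounds 1, 2 and 3, and when the group grows from 9 to 12 heavy atoms and goes from 2 hydrogen-bond donors to 1. No supporting measurement is available to explain why these values remain level.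

The acetyl and the sulfanyl enter together in compound 4, so what each would do alone cannot be read from these compounds. From the compounds shown here alone, it also remains open whether a chain ending in a primary amine, or one carrying a phenyl ring, would stay level with these four or produce a step beyond the scatter.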